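The source may report more compounds than this note shows. Statements on the series, on what has been measured and on what is new or still open speak of the compounds shown alone.

The measured compounds:

compound 1, `Cc1ccc(-c2nn(-c3ccc(Cl)cc3)cc2C(CC(=O)c2ccc(Cl)cc2)C(=O)c2ccc(F)cc2)cc1`, 25.9%
compound 2, `COc1ccc(C(=O)C(CC(=O)c2ccc(Cl)cc2)c2cn(-c3ccc(Cl)cc3)nc2-c2ccc(C)cc2)cc1`, 16.1%
compound 3, `COc1ccc(-c2nn(-c3ccc(S(N)(=O)=O)cc3)cc2C(CC(=O)c2ccc(Cl)cc2)C(=O)c2ccc(F)cc2)cc1`, 72.2%

All three were examined in a functional assay on the whole organism (strain Wistar albino) for inhibition, with Rattus norvegicus as the target, read by paw edema, with stated times of 1 h and 2 h, at a dose of 0.32 mmol/kg by the intraperitoneal route; on this read-out lower numbers stand for less inhibition and higher numbers for more inhibition at the one dose given (going by the name of the read-out). In this assay compound 1 gives 25.9% and compound 2 gives 16.1%. The two share one core and differ only by methoxy in place of fluoro on an aromatic carbon; the resulting step, a number 9.8 percentage points lower from compound 1 to compound 2 (within the scatter), lies within the scatter of the method, so the two values show no real separation. Compound 3 gives 72.2% in this assay, the highest of the three numbers, and its distance from compound 1 and from compound 2 is beyond the scatter in both cases. The difference between the core of compound 3 and the core of compound 1 is not broken down here.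

Compound 4, `COc1ccc(C(=O)C(CC(=O)c2ccc(Cl)cc2)c2cn(-c3ccc(S(N)(=O)=O)cc3)nc2-c2ccc(OC)cc2)cc1`, has not yet been measured. It differs from compound 3 by methoxy in place of fluoro on an aromatic carbon, and the place of the change is the same, word for word, as in the pair of compound 1 and compound 2, so this is the same change made a second time. Since the earlier step, a number 9.8 percentage points lower from compound 1 to compound 2 (within the scatter), stayed within the scatter, a step of similar, small size is expected here as well: a number 8.2 percentage points lower from compound 3 to compound 4 (within the scatter). The wide scatter of a single-dose whole-organism read-out keeps the range broad. On that basis compound 4 is estimated to give 64% in this assay, expected between 46% and 78%.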

Compound 4, a percentage reported as inhibition, in the whole organism at one dose (the size of the read-out at that dose, not a potency): 30.8%
Compound 4: the middle estimate sits 33.2 percentage points above what was measured, and the stated range ends above it.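

In this assay, methoxy in place of fluoro on an aromatic carbon gives a number 41.4 percentage points lower from compound 3 to compound 4 (beyond the scatter), and this step does not match the one seen earlier for the same change on the other core: the same change on two cores in this assay, a number 9.8 percentage points lower (within the scatter) from compound 1 to compound 2 and a number 41.4 percentage points lower (beyond the scatter) from compound 3 to compound 4, 31.6 percentage points apart, beyond the scatter of two such steps

The size of this step therefore cannot be carried from one core to the other in this series, and a small step on one core gave no safe guide to the step on the next. Among the compounds shown here, what this does not show is which part of the difference between the two cores sets the size of the step, or why the step is so much larger on the core of compound 3, since only two pairs are at hand, the two cores differ in more than one place, and a single-dose read-out in the whole organism gives no account of how the change acts.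

The compounds shown leave open how other groups on the same aromatic carbon, such as a hydroxy, an amine, a carboxylic acid or a longer chain like ethoxy, would read in this assay. They also leave open whether the same change gives a small or a large step on a core that differs from the core of compound 3 in only one place.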